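The source may hold more compounds than are shown below. What is called first, only, known or untested is meant among the compounds shown, and "the series" means these compounds.

Measured so far in a functional assay on CHO-K1 cells for antagonist activity at Orexin receptor type 2 (Homo sapiens), read by FLIPR and calcium flux; on this read-out higher numbers stand for weaker inhibition and lower numbers for stronger inhibition:
compound 1, `CCOC(=O)c1ccccc1C(=O)N1C[C@H](Oc2cc(C#N)ccn2)CC[C@H]1C`: 21 nM
compound 2, `CC(C)OC(=O)c1ccccc1C(=O)N1C[C@H](Oc2cc(C#N)ccn2)CC[C@H]1C`: 38 nM

Going by the values given here, compound 2 holds the higher of the two numbers in this assay, yet its only neighbour is compound 1, and the step of a 1.8-fold higher number from compound 1 to compound 2 (0.26 log units; within the scatter) sits within the scatter, so the two compounds cannot be ranked against each other on these data.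

The next compound, compound 3, `C[C@@H]1CC[C@@H](Oc2cc(C#N)ccn2)CN1C(=O)c1ccccc1CC(F)(F)F`, changes a different part of the molecule: 2,2,2-trifluoroethyl in place of isopropoxycarbonyl on an aromatic carbon. Among the compounds with values here, no measured pair exchanges one group for another on the aromatic ring; the single step known, a 1.8-fold higher number from compound 1 to compound 2 (0.26 log units; within the scatter), concerns the ester chain and stays within the scatter. It offers no guide to the direction of the present change, so the expectation is set near compound 2 with a wide band.

Compound 3 is therefore estimated at 45 nM in this assay, with a range of 12 nM to 170 nM, which corresponds to an expected step of a 1.2-fold higher number from compound 2 to compound 3 (0.07 log units; within the scatter).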

Compound 3, half-maximal inhibitory concentration in the Orexin receptor type 2 assay: 32 nM
Compound 3: the middle estimate sits 1.4-fold (0.15 log units) above what was measured, and the stated range covers the measured number.
By their numbers in the Orexin receptor type 2 assay, from the lowest: compounds 1, 3 and 2 (each within the scatter of the next).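

In the Orexin receptor type 2 assay compound 3 gives 32 nM, compound 2 gives 38 nM and compound 1 gives 21 nM. The exchange at this aromatic carbon gives two steps (a 1.2-fold lower number from compound 2 to compound 3 (0.07 log units; within the scatter); a 1.5-fold higher number from compound 1 to compound 3 (0.18 log units; within the scatter)), and both stay within the scatter, so an ester carbonyl is not needed here to keep compound 3 level with compound 1 and compound 2. In a physicochemical assay for lipophilicity, read by HPLC (a lower number here means a more polar compound, a higher number a more lipophilic compound), compound 2 gives 3.6 and compound 3 gives 3.6, and the same exchange gives (no change at the digits printed from compound 2 to compound 3 (within the scatter)), so on these data 2,2,2-trifluoroethyl and isopropoxycarbonyl cannot be told apart in either read-out. No evidence is available on the reason for this result.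

From the compounds shown here alone, whether an amine, a carboxylic acid or a longer chain on this aromatic carbon would give a step beyond the scatter stays open. Going by these compounds, it also stays open how much the nitrile, common to all three compounds, contributes.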